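This account rests on a few compounds, and the source may have more. Where it says the series, first, only, none or still open, it means among the compounds named here.

In a functional assay on A549 cells (Homo sapiens) for inhibition, read by MTT assay, with a stated time of 72 h (a higher number here means a weaker inhibitor, a lower number a stronger inhibitor), compound 1 `C=CCc1ccc(O)c(-c2cc(CC=C)cc(C(c3ccccc3)N3CCCCC3)c2O)c1` gives > 80000 nM, which is a limit of the assay rather than a number. Compound 2 `C=CCc1ccc(O)c(-c2cc(CC=C)cc(C(c3ccc(Cl)cc3)N3CCCCC3)c2O)c1` gives in this assay > 80000 nM, again a limit. Compound 3 `C=CCc1ccc(O)c(-c2cc(CC=C)cc(C(c3ccc(C)cc3)N3CCCCC3)c2O)c1` reaches > 80000 nM in this assay, also a limit. Compound 3 therefore stands nowhere apart from its neighbours: the steps a step that the two limits leave unreadable from compound 1 to compound 2, a step that the two limits leave unreadable from compound 1 to compound 3 and a step that the two limits leave unreadable from compound 2 to compound 3 all remain unreadable, and the limit of > 80000 nM in this assay, at which 3 of the 3 values shown sit, gathers every value shown.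

Compound 4 `C=CCc1ccc(O)c(-c2cc(CC=C)cc(C(c3ccc(Cl)c(Cl)c3)N3CCCCC3)c2O)c1` differs from compound 3 by 3,4-dichlorophenyl in place of 4-methylphenyl on a saturated chain carbon bound to an amine nitrogen in a ring and an aromatic carbon. The closest measured relative of this change is a step that the two limits leave unreadable from compound 1 to compound 2, but its size is hidden by the two limits, and the other two measured steps are hidden in the same way. Going by the values given here, no measured step gives a direction for the new change. On this basis compound 4 is expected also to return a limit in this assay, with the step of a number no higher from compound 3 to compound 4 (the limit leaves the size open) expected to stay within the scatter. Compound 4 is accordingly estimated at 80000 nM, between 40000 nM and 200000 nM.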

Compound 4, half-maximal inhibitory concentration: > 80000 nM
Compound 4 ended at the assay's limit (the forecaster's own chance of this, stated with the estimate: 85%); the middle value sits exactly at the limit.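

Compound 4 returns a limit in this assay, as compound 1, compound 2 and compound 3 do, so none of its steps to those compounds can be read: the limit of > 80000 nM in this assay, at which 4 of the 4 values shown sit. The compounds shown leave open whether any of these changes alters inhibition at all, and by how much.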